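Working notes: one fluoro substitution, one expected outcome

The source may hold more compounds than are shown below. What is called first, only, known or untested is meant among the compounds shown, and "the series" means these compounds.

Measured so far, in a functional assay on the whole organism (strain Swiss) with Mus musculus as the target, in the maximal electroshock model, with a stated time of 0.5 h, at a dose of 100 mg/kg by the intraperitoneal route; on this read-out lower numbers stand for a weaker effect and higher numbers for a stronger effect at the one dose given:
- compound 1 `COCC(C(=O)N1CCN(c2cccc(C(F)(F)F)c2)CC1)N1C(=O)CCC1=O`: 75%
- compound 2 `CC(C(=O)N1CCN(c2ccccc2)CC1)N1C(=O)CCC1=O`: 0%
- compound 3 `CCC(C(=O)N1CCN(c2cccc(F)c2)CC1)N1C(=O)CCC1=O`: 0%

Compound 2 stands level with compound 3 at the digits shown, the two together being the lowest of the three numbers; the gap between them lies within the scatter. Among the measured compounds shown here, the only other number is that of compound 1, which lies well beyond the scatter above compound 2. For the measured compounds named here, no pair among the three differs in a single place, so no single step can be read from these numbers; compound 1 differs from compound 2 in more than one place at once.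

The next compound, compound 4 `CC(C(=O)N1CCN(c2ccc(F)cc2)CC1)N1C(=O)CCC1=O`, differs from compound 2 by fluoro in place of hydrogen on an aromatic carbon. Compound 3 also carries a fluoro on the aromatic ring, with a different chain and a different place on the ring, and it gives the same low number as compound 2. Going by the values given here, nothing among the measured compounds shows a fluoro alone lifting the number.

The expectation is therefore for no step beyond the scatter, or at most a small one upward, from compound 2 to compound 4, as a number 10 percentage points higher from compound 2 to compound 4 (within the scatter) expresses. For compound 4 the estimate in this assay is 10%, ranging from 0% to 40%.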

Compound 4, a percentage reported as activity, at one dose (the size of the read-out at that dose, not a potency): 0%
For compound 4 the middle estimate is 10 percentage points above the measured one; low and high end bracket the measured number.
By their numbers in this assay, from the lowest: compounds 2, 3 and 4 (each within the scatter of the next); then compound 1.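

Among the compounds shown here, this is the first single change that can be read: in this assay phenyl to 4-fluorophenyl gives no change at the digits printed from compound 2 to compound 4 (within the scatter) and nothing more. At this place, on an aromatic carbon para to a large group, fluoro in place of hydrogen therefore does not separate the two compounds at the one dose and time given, on the chain and core that compound 2 carries. No independent measurement bears on why this change leaves the read-out as it is.

The steps that would connect compound 1 with the other compounds cannot be read, as it differs from each of them in more than one place, so its high number cannot be assigned to its chain or to its ring substituent. Still open, from the compounds shown here alone, are whether a chloro, a trifluoromethyl or an amine at this same place, or a longer chain on the core of compound 2, would lift the number, and whether fluoro at this place would count at all on a compound that starts from a measurable effect.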